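This account rests on a few compounds, and the source may have more. Where it says the series, first, only, none or still open, it means among the compounds named here.

Measured compounds and their numbers:

compound 1, `CCC(=O)N(C)c1ccc2[nH]c(-c3n[nH]c4ccccc34)cc2n1`: 33500 nM
compound 2, `COc1cccc(C(=O)N(C)c2ccc3[nH]c(-c4n[nH]c5ccccc45)cc3n2)c1`: 22000 nM
compound 3, `CN(c1ccc2[nH]c(-c3n[nH]c4ccccc34)cc2n1)S(=O)(=O)c1ccccc1`: 12000 nM

All three share the same core and differ only in the group attached to the methylated nitrogen on the aromatic ring. In a functional assay on SMMC-7721 cells (Homo sapiens) for antiproliferative activity, read by MTT assay, with a stated time of 72 h (a higher number here means a weaker inhibitor, a lower number a stronger inhibitor), compound 3 gives the lowest of the three numbers. Its distance from compound 1, a 2.8-fold lower number from compound 1 to compound 3 (0.45 log units; beyond the scatter), is beyond the usual scatter, whereas its distance from compound 2, a 1.8-fold lower number from compound 2 to compound 3 (0.26 log units; within the scatter), is not, so compound 3 and compound 2 cannot be ranked against each other.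

Compound 4, `COc1ccc(OC)c(S(=O)(=O)N(C)c2ccc3[nH]c(-c4n[nH]c5ccccc45)cc3n2)c1`, keeps the sulfonyl linkage of compound 3 and alters only the ring on it: 2,5-dimethoxyphenyl in place of phenyl on a sulfonyl sulfur. Among the measured compounds shown here, none of the measured steps changes the ring on a sulfonyl sulfur. For the measured compounds named here, the only step that swaps a plain group for one carrying a methoxy-substituted ring is the carbonyl-side exchange from compound 1 to compound 2, a 1.5-fold lower number from compound 1 to compound 2 (0.18 log units; within the scatter), which stayed within the scatter. By that analogy, no step beyond the scatter is expected in this assay for compound 4. Compound 4 is therefore estimated at 10000 nM, with a range from 4000 nM to 25000 nM. The expected step is a 1.2-fold lower number from compound 3 to compound 4 (0.08 log units; within the scatter), an estimate rather than a measurement.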

Compound 4, half-maximal inhibitory concentration: 4280 nM
Compound 4: the middle estimate sits 2.3-fold (0.37 log units) above what was measured; the range from low to high includes it.
By their numbers in this assay, from the lowest: compound 4; then compounds 3, 2 and 1 (each within the scatter of the next, the first and the last beyond it).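

The ring on the sulfonyl sulfur matters in this assay: with the shared core and the sulfonamide nitrogen left as they were, 2,5-dimethoxyphenyl in place of phenyl gives a 2.8-fold lower number from compound 3 to compound 4 (0.45 log units; beyond the scatter). The earlier steps shown here exchanged the whole group on the nitrogen, and only one of them, from compound 1 to compound 3, went beyond the scatter, so they could not show whether the ring alone could shift the number; this pair shows that it can, although the step is modest and the number stays in the micromolar range. Nothing available here explains the size or direction of this step.

From the compounds shown here alone, the two methoxy groups enter together, so the effect of either one alone remains open, as does the outcome with other groups on this ring, such as a fluorine, an amine or a carboxylic acid. Also open, going by these compounds, is whether a 2,5-dimethoxyphenyl group on a carbonyl carbon, in place of the sulfonyl link, would give a similar step, and what a longer chain in place of the methyl on the nitrogen would do.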